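A Ring Swap at the Edge of Measurement

A few compounds are considered here, and "the series" means these few. Any claim that something is new, unique, unknown or untested is made for them only; others in the source may bear on it.

Compound 1 `Cc1cc(-c2c(C#N)nn(C)c2C)ccc1-c1nnc(N(C)Cc2ccc3nccn3c2)o1` gives 6310 nM in an assay on COS-7 cells for inhibition of tyrosine-protein kinase receptor UFO (Homo sapiens), read by ELISA, with a stated time of 1 h; a higher number here means a weaker inhibitor, a lower number a stronger inhibitor.
Compound 2 `Cc1cc(-c2c(C)nn(C(F)F)c2C)ccc1-c1nnc(N(C)Cc2ccc3nccn3c2)o1` gives > 10000 nM in this assay, a limit of the assay rather than a number.

Compound 2 therefore stands at the ceiling of what this assay reports, as the limit of > 10000 nM in this assay, at which 1 of the 2 values shown sits, shows; the step of an at least 1.5-fold higher number from compound 1 to compound 2 (0.19 log units; that floor lies within the scatter) is only a floor and lies within the scatter. Compound 3 `Cc1cc(-c2c(C)nc(C)n2C)ccc1-c1nnc(N(C)Cc2ccc3nccn3c2)o1` is not yet measured. It differs from compound 2 by 1,2,4-trimethyl-1H-imidazol-5-yl in place of 1-(difluoromethyl)-3,5-dimethyl-1H-pyrazol-4-yl on an aromatic carbon. Going by the values given here, the only measured step that bears on this position is that from compound 1 to compound 2, where one five-membered ring replaced another on the same aromatic carbon and the number did not move beyond the scatter. For compound 3 the expectation is therefore no step beyond the scatter, a number no higher from compound 2 to compound 3 (the limit leaves the size open). Compound 3 is estimated at 10000 nM in this assay, with a range from 3000 nM to 30000 nM.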

Compound 3, half-maximal inhibitory concentration in the tyrosine-protein kinase receptor UFO assay: 5010 nM
For compound 3 the middle estimate is 2.0-fold (0.30 log units) above the measured one; the measured number falls inside the stated range.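

In the tyrosine-protein kinase receptor UFO assay the change to 1,2,4-trimethyl-1H-imidazol-5-yl gives an at least 1.9-fold lower number from compound 2 to compound 3 (0.30 log units; that floor lies within the scatter), and a 1.3-fold lower number from compound 1 to compound 3 (0.10 log units; within the scatter), so none of the swaps among these three five-membered aromatic rings on this aromatic carbon gives a step beyond the scatter. The same change lowers lipophilicity far more clearly, as a physicochemical assay for lipophilicity, at pH 7.4 (a higher number here means a more lipophilic compound, a lower number a more polar compound), shows: the measured distribution coefficient of compound 2, 4.1, and of compound 3, 2.6, a number 1.50 log units lower (beyond the scatter) In the physicochemical assay compound 2 gives 4.1 and compound 3 gives 2.6. Compound 2 gives only a limit in the tyrosine-protein kinase receptor UFO assay, not a number: the limit of > 10000 nM in the tyrosine-protein kinase receptor UFO assay, at which 1 of the 3 values shown sits.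

The compounds shown leave open whether any group on this aromatic carbon can bring the number in the tyrosine-protein kinase receptor UFO assay far under the values seen here. They also leave open what a ring carrying an amine or a carboxylic acid would do at this place, in either measurement.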